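This account rests on a few compounds, and the source may have more. Where it says the series, first, only, none or still open, it means among the compounds named here.

Working notes on the series. The shared core of compound 1 `CC(C)C1c2ncn(Cc3ccccc3)c2NC(=O)N1Cc1ccccc1` carries two benzyl groups, and in a functional assay on K562 cells (Homo sapiens) for cytotoxicity, read by thymidine incorporation, with a stated time of 48 h, tested at 10 ug/mL (on this read-out lower numbers stand for less inhibition and higher numbers for more inhibition at the one concentration tested (going by the name of the read-out)), compound 1 gives 51%. Compound 2 `O=c1nc2c(ncn2Cc2ccccc2)c(C#Cc2ccccc2)n1Cc1ccccc1` in this assay gives 100%, and compound 3 `O=c1nc2c(ncn2Cc2ccccc2)c(C#CC2CC2)n1Cc1ccccc1` gives 97%. Compound 3 stands second highest of the three numbers, nearest to compound 2 and furthest from compound 1.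

For the measured compounds named here, the only single-point step measured is a number 3 percentage points lower from compound 2 to compound 3 (within the scatter), so a change at the position of the triple bond has not moved the number so far. The next compound, compound 4 `O=c1nc2c(ncn2Cc2ccccc2)c(C(F)(F)F)n1Cc1ccccc1`, differs from compound 3 as trifluoromethyl in place of 2-cyclopropylethynyl on an aromatic carbon. Going by the values given here, no measured step exchanges the whole ethynyl group for a trifluoromethyl group, so the measured step bears on it only loosely; compound 1, with a different core, shows that the read-out can fall well below compound 3.

For compound 4 in this assay the expected step is a number 22 percentage points lower from compound 3 to compound 4 (beyond the scatter), a drop that is uncertain in size. The estimated value for compound 4 is 75%, with a range from 40% to 100%.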

Compound 4, a percentage reported as inhibition, at one concentration (the size of the read-out at that concentration, not a potency): 11%
Compound 4: the middle estimate sits 64 percentage points above what was measured; measured number below the stated range.
By their numbers in this assay, from the lowest: compound 4; then compound 1; then compounds 3 and 2 (each within the scatter of the next).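

In this assay the aromatic carbon ortho to a benzyl group turns out to be sensitive to the change: trifluoromethyl in place of 2-cyclopropylethynyl gives a number 86 percentage points lower from compound 3 to compound 4 (beyond the scatter) and trifluoromethyl in place of 2-phenylethynyl gives a number 89 percentage points lower from compound 2 to compound 4 (beyond the scatter) in the same direction. The earlier exchange of phenyl for cyclopropyl on the triple-bonded carbon stayed within the scatter, so the group at the far end of the triple bond can vary without a measured change, while losing the whole ethynyl group cannot. Nothing measured here accounts for the size of this drop.

Whether the triple bond itself is needed stays open, as the compounds shown hold no saturated chain such as 2-cyclopropylethyl at this carbon. As far as these compounds go, how an amine, a nitrile or a plain methyl would read at this carbon is also open.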